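Swapping Benzyl for Phenyl on the Shared Core

The source may report more compounds than this note shows. Statements on the series, on what has been measured and on what is new or still open speak of the compounds shown alone.

Compound 2 `Nc1cccc(-c2cn3nc(Cc4ccccc4)sc3n2)c1` gives 37000 nM in a functional assay on CCRF-CEM cells (Homo sapiens) for inhibition, read by cell counting, with a stated time of 3 days (on this read-out lower numbers stand for stronger inhibition and higher numbers for weaker inhibition), and stands lowest of the two numbers shown. Compound 3 `COc1cccc(Cc2nn3cc(-c4cccc(N)c4)nc3s2)c1` gives 40000 nM, and the step of a 1.1-fold higher number from compound 2 to compound 3 (0.03 log units; within the scatter) lies within the scatter. Compound 1 `Nc1cccc(-c2cn3nc(-c4ccc(F)cc4)sc3n2)c1` gave no number in this assay but a limit, >= 250000 nM. The unmeasured compound 4 `Nc1cccc(-c2cn3nc(-c4ccccc4)sc3n2)c1` differs from compound 2 by phenyl in place of benzyl on an aromatic carbon. Within the data shown here, the one measured step that bears on this change is an at least 6.7-fold lower number from compound 1 to compound 2 (0.82 log units; beyond the scatter), where benzyl replacing 4-fluorophenyl lowered the number beyond the scatter; compound 4 returns to a directly attached ring, so the reverse is expected. Compound 4 is therefore estimated at 150000 nM, between 50000 nM and 400000 nM, an expected step of a 4.1-fold higher number from compound 2 to compound 4 (0.61 log units; beyond the scatter) toward weaker inhibition, with a fair chance that this assay again reports a limit.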

Compound 4, half-maximal inhibitory concentration: 33000 nM
The estimate for compound 4 lay 4.5-fold (0.66 log units) above the measured number, and the stated range ends above it.
By their numbers in this assay, from the lowest: compounds 4, 2 and 3 (each within the scatter of the next). At a limit, above all of these: compound 1.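

Phenyl and benzyl on this aromatic carbon read alike in this assay, with a 1.1-fold lower number from compound 2 to compound 4 (0.05 log units; within the scatter). Hydrogen in place of fluoro gives an at least 7.5-fold lower number from compound 1 to compound 4 (0.87 log units; beyond the scatter), so the earlier gap between compound 1 and compound 2 follows the fluoro rather than the benzyl. That step rests on compound 1, which gave only a limit: the limit of >= 250000 nM in this assay, at which 1 of the 4 values shown sits.

Going by these compounds, whether 4-chlorophenyl would share the fate of 4-fluorophenyl remains open. So does whether a longer chain such as phenethyl, or a carboxylic acid on the phenyl ring, would move the number at all.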